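Inverting Both Stereocentres of Compound 1

A few compounds are considered here, and "the series" means these few. Any claim that something is new, unique, unknown or untested is made for them only; others in the source may bear on it.

- Compound 1 `Cc1cc(C)c(CN2CCc3c(Cl)cc([C@H](CO)[C@H]4CCOC4)c(Cl)c3C2=O)c(=O)[nH]1`: 15 nM
- Compound 2 `COC(c1cc(Cl)c2c(c1Cl)C(=O)N(Cc1c(C)cc(C)[nH]c1=O)CC2)C1CCOCC1`: 1150 nM; 19 nM (2 entries)
- Compound 3 `Cc1cc(C)c(CN2CCc3c(Cl)cc(C(CO)c4ccon4)c(Cl)c3C2=O)c(=O)[nH]1`: 2490 nM; 122 nM (2 entries)

For the measured compounds named here, in a functional assay on KARPAS-422 cells (Homo sapiens) for antiproliferative activity, read by resazurin assay, with a stated time of 72 h (a higher number here means a weaker inhibitor, a lower number a stronger inhibitor), compound 1 gives 15 nM, its only single number, and two further entries for it carry no single number. Compound 4 `Cc1cc(C)c(CN2CCc3c(Cl)cc([C@@H](CO)[C@@H]4CCOC4)c(Cl)c3C2=O)c(=O)[nH]1` has the same atoms and bonds as compound 1: the two compounds have the same atoms and bonds and differ only in configuration as drawn: 2 of 2 stereo elements differ (all stereocentres are inverted: mirror images); a stereocentre at a saturated chain carbon is drawn R in compound 1 and S in compound 4; a stereocentre at a saturated ring carbon is drawn R in compound 1 and S in compound 4. Going by the values given here, no measured pair isolates such an inversion. Still, compound 2, drawn without configuration, shows a wide spread (the several entries of compound 2 in this assay, 1150 nM; 19 nM (2 entries)), and compound 3, also drawn without configuration, shows another (the several entries of compound 3 in this assay, 2490 nM; 122 nM (2 entries)). A clear loss of potency beyond the scatter is therefore expected, with the estimated step of a 67-fold higher number from compound 1 to compound 4 (1.82 log units; beyond the scatter). For compound 4 the expected value is 1000 nM, with an estimated range of 150 nM to 5000 nM.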

Compound 4, half-maximal inhibitory concentration: 3950 nM
For compound 4 the middle estimate is 4.0-fold (0.60 log units) below the measured one; low and high end bracket the measured number.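

In this assay, inverting both stereocentres gives a 260-fold higher number from compound 1 to compound 4 (2.42 log units; beyond the scatter), so configuration alone separates the two compounds at this position, with no atom or bond changed: the fact that compounds 1 and 4 differ only in the configuration as drawn. This is the first measured pair to isolate such an inversion, where a wide spread for a compound drawn without configuration could only hint at it: the several entries of compound 2 in this assay, 1150 nM; 19 nM (2 entries)

As far as these compounds go, both stereocentres change together, so it stays open whether the saturated chain carbon or the saturated ring carbon accounts for the step. Also open, from the compounds shown here alone, is whether the same preference would hold with an amine or a carboxylic acid on the chain.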